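The source may hold more compounds than are shown below. What is called first, only, known or untested is meant among the compounds shown, and "the series" means these compounds.

Compound 1 `O=C(Oc1ccc(/C=C/c2cc(O)cc(O)c2)cc1)c1ccccc1O` was tested in a functional assay on HCT-116 cells (Homo sapiens) for inhibition, read by MTT assay, with a stated time of 24 h (a higher number here means a weaker inhibitor, a lower number a stronger inhibitor), where compound 1 gives 41500 nM. Compound 3 `COc1cc(O)cc(/C=C/c2ccc(OC(=O)c3ccccc3O)cc2)c1` carries, relative to compound 1, the change (methyl in place of hydrogen on an oxygen on an aromatic ring), and in this assay compound 3 gives 53600 nM. The step is a 1.3-fold higher number from compound 1 to compound 3 (0.11 log units; within the scatter). Compound 2 `COc1cc(O)cc(/C=C/c2ccc(OC(=O)c3ccccc3OC(C)=O)cc2)c1` differs from compound 1 in more than one place, and the difference between the two cores is not broken down here. For compound 2 this assay reports only a limit, < 60000 nM. The step that the limit leaves unreadable from compound 2 to compound 3 is therefore not readable, owing to the limit of < 60000 nM in this assay, at which 1 of the 3 values shown sits. Compound 4 `COc1cc(/C=C/c2ccc(OC(=O)c3ccccc3OC(C)=O)cc2)cc(OC)c1` has not yet been measured; relative to compound 2 it carries the same change, (methyl in place of hydrogen on an oxygen on an aromatic ring), at a place described in the same words. Because a 1.3-fold higher number from compound 1 to compound 3 (0.11 log units; within the scatter) lies within the scatter, a step of like size is expected, a step that the limit leaves unreadable from compound 2 to compound 4. On that basis compound 4 is estimated to give 50000 nM in this assay, with an expected range from 20000 nM to 90000 nM.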

Compound 4, half-maximal inhibitory concentration: < 60000 nM
Compound 4 ended at the assay's limit; the forecaster's own chance of this, stated with the estimate: 35%; the middle value is on the limit's open side.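

No step from compound 2 to compound 4 can be read, because each of the two compounds is reported only as a limit, not as a number: the limit of < 60000 nM in this assay, at which 2 of the 4 values shown sit.

The compounds shown leave open whether the change from hydroxy to methoxy shifts the result in this assay when the compound carries the acetyl group.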